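The source may hold more compounds than are shown below. What is called first, only, known or untested is meant among the compounds shown, and "the series" means these compounds.

Working notes on the shared core. Compound 1 `CCC(C)C(NC(=O)n1nnc2ccccc21)C(=O)NC1CCCCC1` gives in a functional assay on HeLa cells (Homo sapiens) for inhibition (a higher number here means a weaker inhibitor, a lower number a stronger inhibitor), 63900 nM. Compound 2 `CCC(C)C(NC(=O)n1nnc2ccccc21)C(=O)NCc1ccccc1` sits at the limit of this assay, >= 100000 nM, which is a limit and not a number, as the limit of >= 100000 nM in this assay, at which 1 of the 3 values shown sits, records. The step of an at least 1.5-fold higher number from compound 1 to compound 2 (0.19 log units; that floor lies within the scatter) is therefore known only as a floor. Compound 3 `CC(C)C(NC(=O)n1nnc2ccccc21)C(=O)NC1CCCC1` gives in this assay 96400 nM, the highest of the two numbers, though its gap to compound 1 lies within the scatter. Compound 4 `CCC(C)C(NC(=O)n1nnc2ccccc21)C(=O)NC1CCCC1` differs from compound 3 by methyl in place of hydrogen on a saturated chain carbon, three bonds along the chain from an amide-type nitrogen and a carbonyl carbon. Among the compounds with values here, no measured step covers this change, and the single measured step concerns a different position, so no shift beyond the scatter is expected. For compound 4 the expected step is a 1.2-fold lower number from compound 3 to compound 4 (0.08 log units; within the scatter), giving an estimate of 80000 nM within 40000 nM to 160000 nM.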

Compound 4, half-maximal inhibitory concentration: 82300 nM
The estimate for compound 4 lay 1.0-fold (0.01 log units) below the measured number; low and high end bracket the measured number.
By their numbers in this assay, from the lowest: compounds 1, 4 and 3 (each within the scatter of the next). At a limit, above all of these: compound 2.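

In this assay, methyl in place of hydrogen on a saturated chain carbon, three bonds along the chain from an amide-type nitrogen and a carbonyl carbon, gives a 1.2-fold lower number from compound 3 to compound 4 (0.07 log units; within the scatter), so isopropyl to sec-butyl stays within the scatter with cyclopentyl on the amide-type nitrogen. Cyclopentyl in place of cyclohexyl gives a 1.3-fold higher number from compound 1 to compound 4 (0.11 log units; within the scatter), also within the scatter. Cyclopentyl in place of benzyl gives an at least 1.2-fold lower number from compound 2 to compound 4 (0.08 log units; that floor lies within the scatter), and the start of that step is a limit, not a number: the limit of >= 100000 nM in this assay, at which 1 of the 4 values shown sits.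

The compounds shown leave open whether a longer chain or a carboxylic acid on this chain carbon would move the number beyond the scatter.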